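Phenyl for methyl on two related pyrazoline cores

A few compounds are considered here, and "the series" means these few. Any claim that something is new, unique, unknown or untested is made for them only; others in the source may bear on it.

Of the compounds shown here, three have been tested in a functional assay on the whole organism (strain albino) for inhibition, with Rattus norvegicus as the target, read by paw edema, with stated times of 30 min and 1 h, at a dose of 25 mg/kg by the intraperitoneal route; a higher number here means more inhibition at the dose given (going by the name of the read-out), a lower number less inhibition. Compound 1 `COc1ccc(C2=NN(C(=O)NS(=O)(=O)c3ccc(Cl)cc3)CC2c2ccccc2)c(OC)c1` carries a phenyl on a saturated ring carbon and gives 24.2% in this assay. Compound 2 `COc1ccc(C2=NN(C(=O)NS(=O)(=O)c3ccc(Cl)cc3)CC2C)c(OC)c1` carries a methyl at that same place and gives 12.3%. The change between them is phenyl in place of methyl on a saturated ring carbon, and it made a step of a number 11.9 percentage points higher from compound 2 to compound 1 (beyond the scatter).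

Compound 3 `COc1ccc(C2=NN(C(=S)NC(=O)c3ccc(Cl)cc3)CC2C)c(OC)c1` is built on a different core, and the difference between the two cores is not broken down here. In this assay compound 3 gives 0%, the lowest of the three numbers, with both the others beyond the scatter above it.

Compound 4 `COc1ccc(C2=NN(C(=S)NC(=O)c3ccc(Cl)cc3)CC2c2ccccc2)c(OC)c1` has not been measured. It differs from compound 3 by phenyl in place of methyl on a saturated ring carbon, the same kind of change that turns compound 2 into compound 1. The two places are described in the same words, so the change is the same in its setting as well. For the measured compounds named here, only this one earlier example exists, so the expectation rests on a single step. For compound 4 the estimated step is a number 12 percentage points higher from compound 3 to compound 4 (beyond the scatter), expected to be of a size close to the earlier one because compound 1 rose over compound 2 by a number 11.9 percentage points higher from compound 2 to compound 1 (beyond the scatter). Compound 4 is therefore estimated at 12%, with a range from 0% to 26% allowing for the scatter and for the different core.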

Compound 4, a percentage reported as inhibition, in the whole organism at one dose (the size of the read-out at that dose, not a potency): 0%
The estimate for compound 4 lay 12 percentage points above the measured number, and the stated range covers the measured number.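

In this assay, phenyl in place of methyl on a saturated ring carbon gave no change at the digits printed from compound 3 to compound 4 (within the scatter), whereas on the core of compound 1 the same change gave a number 11.9 percentage points higher from compound 2 to compound 1 (beyond the scatter). Read alone, this might suggest that the gain belongs to one core and does not carry over, but a single pair on each core cannot settle that, and the two steps cannot be told apart at this level of scatter: the same change on two cores in this assay, a number 11.9 percentage points higher (beyond the scatter) from compound 2 to compound 1 and no change at the digits printed (within the scatter) from compound 3 to compound 4, 11.9 percentage points apart, within the scatter of two such steps. So the result neither shows that the change transfers between these cores nor shows that it fails to, and with compound 3 at 0% and compound 4 at 0%, it gives no sign of any gain on the core of compound 3 at this single dose.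

The compounds shown leave open how a group of another kind, such as an ethyl chain, a benzyl group or a longer chain, would behave at the same saturated ring carbon on either core. They also leave open whether an amine or a carboxylic acid on the added phenyl would change the picture, and which part of the difference between the two cores matters.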